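The compounds below may be only part of what the source reports. "The series", "measured", "known", "first", "only" and "open" are said of these compounds alone.

Measured compounds in a functional assay on SW-620 cells (Homo sapiens) for antiproliferative activity, read by MTT assay, with a stated time of 72 h; on this read-out higher numbers stand for weaker inhibition and lower numbers for stronger inhibition:
Compound 1 `COc1cc(CC(O)(COCc2ccccc2)COCc2ccccc2)nc(OC)n1` gives > 100000 nM, a limit of the assay.
Compound 2 `O=c1cc(CC(O)(COCc2ccccc2)COCc2ccccc2)[nH]c(=O)[nH]1` gives > 100000 nM, a limit of the assay.
Compound 3 `COc1cc(CC(COCc2ccccc2)COCc2ccccc2)nc(OC)n1` gives > 100000 nM, a limit of the assay.

Compound 3 stands at the limit of this assay, with no number of its own. The other two values sit at the same limit, as the limit of > 100000 nM in this assay, at which 3 of the 3 values shown sit, records, so none of the three can be told apart from another. The step to compound 4 `O=c1cc(CC(COCc2ccccc2)COCc2ccccc2)[nH]c(=O)[nH]1` is a group of 8 heavy atoms (4 carbon, 2 nitrogen, 2 oxygen; one six-membered aromatic ring with 2 hetero atoms) in place of a group of 10 heavy atoms (6 carbon, 2 nitrogen, 2 oxygen; one six-membered aromatic ring with 2 hetero atoms), on a saturated chain carbon, three bonds along the chain from two oxygens on a saturated carbon. The same exchange of the aromatic group has been run once already, as a step that the two limits leave unreadable from compound 1 to compound 2; the removal of hydroxy, a step that the two limits leave unreadable from compound 1 to compound 3, is likewise unreadable. Neither measured step yields a size or a direction, so the expectation for compound 4 is that it stays at the limit, with an expected step of a number no higher from compound 3 to compound 4 (the limit leaves the size open) that cannot be separated from none. Compound 4 is therefore expected at 100000 nM, with a range from 30000 nM to 300000 nM.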

Compound 4, half-maximal inhibitory concentration: > 100000 nM
Compound 4: a limit, no number (the forecaster's own chance of this, stated with the estimate: 85%); the middle value lies on the limit itself.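

In this assay no new step can be read for compound 4 against compound 2 or compound 3, since all four compounds share one limit: the limit of > 100000 nM in this assay, at which 4 of the 4 values shown sit.

The compounds shown leave open what size or direction either the aromatic group exchange or the removal of hydroxy has in this series.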